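A few compounds are considered here, and "the series" means these few. Any claim that something is new, unique, unknown or untested is made for them only; others in the source may bear on it.

In a functional assay on Raji cells (Homo sapiens) for cytotoxicity, with a stated time of 72 h (on this read-out lower numbers stand for an effect already at smaller amounts and higher numbers for an effect only at larger amounts of compound), compound 1 `C=C[C@@](C)(/C=C/c1ccc(Nc2cccc(OC(F)(F)F)c2)cc1)CCC=C(C)C` gives > 26000 nM, a limit of the assay rather than a number. Compound 2 `C=C[C@@](C)(/C=C/c1ccc(Nc2ccc(OC(F)(F)F)cc2)cc1)CCC=C(C)C` gives > 26000 nM, again only a limit. Compound 3 `C=C[C@@](C)(/C=C/c1ccc(Nc2ccc(C(F)(F)F)cc2)cc1)CCC=C(C)C` gives > 26000 nM, likewise a limit. Compound 3 differs from compound 2 by trifluoromethyl in place of trifluoromethoxy on an aromatic carbon and the step that the two limits leave unreadable from compound 2 to compound 3 stays unreadable because of the limit of > 26000 nM in this assay, at which 3 of the 3 values shown sit. The difference between the cores of compound 1 and compound 2 is not broken down here. Compound 4 `C=C[C@@](C)(/C=C/c1ccc(Nc2cccc(C(F)(F)F)c2)cc1)CCC=C(C)C` is not yet measured; it differs from compound 1 by trifluoromethyl in place of trifluoromethoxy on an aromatic carbon, the same kind of change as that of compound 3, though here meta to a large group rather than para to a large group. Beside that unreadable step, the step from compound 1 to compound 4 is expected to be a step that the limit leaves unreadable from compound 1 to compound 4, resting on compound 1 standing at the limit > 26000 nM in this assay. For compound 4 the estimate is 40000 nM, between 15000 nM and 150000 nM.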

Compound 4, half-maximal effective concentration: > 26000 nM
Compound 4: no number, only a limit (the forecaster's own chance of this, stated with the estimate: 85%); the middle value lies beyond the limit too.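

Among the compounds shown here, compound 1 and compound 4 each stand only at a limit in this assay, so no step between them can be read. The compounds shown leave open whether trifluoromethyl and trifluoromethoxy differ at all in this cytotoxicity read-out.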